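A few compounds are considered here, and "the series" means these few. Any claim that something is new, unique, unknown or untested is made for them only; others in the source may bear on it.

Working notes on the series. Compound 1 `CCCn1c(=O)c(S(=O)(=O)c2ccc(F)cc2F)cc2cnc(Nc3ccc4[nH]ccc4c3)nc21` holds the lowest number of the two measured; in a functional assay on K562 cells (Homo sapiens) for inhibition, read by trypan blue exclusion, with a stated time of 72 h (on this read-out lower numbers stand for stronger inhibition and higher numbers for weaker inhibition), compound 1 gives 1000 nM. Compound 2 `COC(=O)Cn1ccc2cc(Nc3ncc4cc(S(=O)(=O)c5ccc(F)cc5F)c(=O)n(C)c4n3)ccc21` gives 5000 nM in this assay, a higher number beyond the scatter. Compound 3 `COC(=O)Cn1c(=O)c(S(=O)(=O)c2ccc(F)cc2F)cc2cnc(Nc3ccc4[nH]ccc4c3)nc21` has not been measured in this assay. Against compound 1 it shows (methoxycarbonyl in place of ethyl on a saturated chain carbon bound to an aromatic nitrogen). Among the compounds with values here, no measured pair covers this change, so the direction is open; the step of a 1.5-fold higher number from compound 1 to compound 3 (0.18 log units; within the scatter) is expected to stay within the scatter, if anything toward a higher number. For compound 3 in this assay the estimate is 1500 nM, with a range from 500 nM to 5000 nM.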

Compound 3, half-maximal inhibitory concentration: 5000 nM
Estimate against measurement, compound 3: 3.3-fold (0.52 log units) below, within the range that was stated.
By their numbers in this assay, from the lowest: compound 1; then compounds 2 and 3 (each within the scatter of the next).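

In this assay, the substituent on this saturated chain carbon bound to an aromatic nitrogen affects the read-out: methoxycarbonyl in place of ethyl gives a 5.0-fold higher number from compound 1 to compound 3 (0.70 log units; beyond the scatter). Within the data shown here, this is the first single-place comparison at this position, and it goes against the ester, which brings in two hydrogen-bond acceptors and a double bond. Nothing measured here accounts for the size of this step. Still open, on these data alone, is whether the ester itself or only the added chain length drives the step. A carboxylic acid, an amine or a longer alkyl chain at this position could separate these readings.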